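The source may hold more compounds than are shown below. What is called first, only, known or untested is meant among the compounds shown, and "the series" means these compounds.

Compound 2 `Nc1cc(N)c2nc(-c3ccccc3)c(NCc3ccc(F)cc3)nc2c1` is measured in a functional assay on K562 cells (Homo sapiens) for inhibition, read by sulforhodamine B assay, with a stated time of 48 h (a higher number here means a weaker inhibitor of growth, a lower number a stronger inhibitor of growth), where it shows only a limit of the assay, < 100000 nM. Compound 1 `Nc1cc(N)c2nc(-c3ccccc3)c(Oc3ccc(Cl)c(Cl)c3)nc2c1` likewise gives only a limit there, < 100000 nM. Compound 3 `COc1ccc(CNc2nc3cc(N)cc(N)c3nc2-c2ccccc2)cc1` gives 97700 nM in this assay. The steps a step that the two limits leave unreadable from compound 1 to compound 2 and a step that the limit leaves unreadable from compound 2 to compound 3 cannot be sized, since two of the three values sit at a limit (the limit of < 100000 nM in this assay, at which 2 of the 3 values shown sit). Compound 4 `COc1ccc(Sc2nc3cc(N)cc(N)c3nc2-c2ccccc2)cc1` differs from compound 2 by (4-methoxyphenyl)sulfanyl in place of (4-fluorobenzyl)amino on an aromatic carbon. Going by the values given here, no measured step covers this exchange, and the values of compounds 1, 2 and 3 all lie at or close to the limit. Compound 4 is therefore expected to show a step that the limit leaves unreadable from compound 2 to compound 4 that stays within the scatter, with an estimated value of 80000 nM, between 20000 nM and 100000 nM in this assay.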

Compound 4, concentration for total growth inhibition: < 100000 nM
Compound 4: no number, only a limit (the forecaster's own chance of this, stated with the estimate: 50%); the middle value is on the limit's open side.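

In this assay compound 4, like compound 1 and compound 2, gives only a limit, so no new step can be read: the limit of < 100000 nM in this assay, at which 3 of the 4 values shown sit. Which of the (4-methoxyphenyl)sulfanyl, (4-fluorobenzyl)amino and 3,4-dichlorophenoxy groups gives the stronger inhibitor of growth stays open.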